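Bromo in place of chloro on compound 2

The compounds below may be only part of what the source reports. "The series", "measured", "known", "first", "only" and "open" are said of these compounds alone.

Measured so far in a functional assay on the whole organism with Mus musculus as the target; a higher number here means that more compound is needed for the effect, a lower number that less compound is needed
compound 1 (`CC(=O)NC1=NC(c2ccccc2)CN1`) gives 111 mg/kg
compound 2 (`COC(=O)NC1=NC(c2cccc(Cl)c2)CN1`) gives 40 mg/kg
compound 3 (`COC(=O)NC1=NC(c2ccccc2Br)CN1`) gives 49 mg/kg

Compound 2 stands at 40 mg/kg in this assay and lies within the scatter of compound 3. Compound 1 has the higher number compared with compound 2, and that gap lies beyond the scatter. Going by the values given here, no two measured compounds differ in one place only, so no measured step speaks directly to the next exchange.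

Compound 4 (`COC(=O)NC1=NC(c2cccc(Br)c2)CN1`) follows from compound 2 through bromo in place of chloro on an aromatic carbon as the whole change, which is bromo in place of chloro on an aromatic carbon, meta to a large group. The only support is indirect. Compound 3 also carries bromo, on a different aromatic carbon, and its 49 mg/kg stays within the scatter of compound 2. Three compounds are a thin basis, so the range is kept wide. No step beyond the scatter is expected, and the estimate means an expected step of a 1.1-fold higher number from compound 2 to compound 4 (0.02 log units; within the scatter) of a size within the scatter. Compound 4 is estimated at 42 mg/kg with an expected range from 22 mg/kg to 80 mg/kg in this series.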

Compound 4, dose for half-maximal effect: 28 mg/kg
Beside the measured number, compound 4's estimate is 1.5-fold (0.18 log units) above it, and the stated range covers the measured number.
By their numbers in this assay, from the lowest: compounds 4, 2 and 3 (each within the scatter of the next); then compound 1.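

In this assay, bromo in place of chloro on an aromatic carbon, meta to a large group, gives a 1.4-fold lower number from compound 2 to compound 4 (0.15 log units; within the scatter). Going by these compounds alone, this is the first direct one-place reading: at this position the two halogens are not separated by this measure, so the exchange is tolerated, whereas the earlier compounds could speak to it only indirectly. No measurement of any property of these compounds bears on this step.

The compounds shown leave open what a smaller or quite different group on this same aromatic carbon would give, such as fluoro, methoxy or an amine, and whether a plain hydrogen there would read any differently from either halogen. Also open, from the compounds shown here alone, is whether bromo in place of chloro gives a step of similar size on the other aromatic carbon, the one that carries bromo in compound 3, and whether the same holds with another group in place of the methyl ester part of the side chain, such as a longer alkyl chain.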